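A Methoxy to Phenyl Swap on a Cytotoxicity Plateau

A few compounds are considered here, and "the series" means these few. Any claim that something is new, unique, unknown or untested is made for them only; others in the source may bear on it.

Compound 1 `C=C[C@@](C)(/C=C/c1ccc(OC)cc1)CCC=C(C)C` is the starting point. In a functional assay on HepG2 cells (Homo sapiens) for cytotoxicity, with a stated time of 72 h (a higher number here means that more compound is needed for the effect, a lower number that less compound is needed), compound 1 gives > 52000 nM, which is a limit of the assay rather than a number. Two further compounds sit at the same limit. Compound 2 `CC(C)=CCC[C@](C)(/C=C/c1ccc(O)cc1)/C=C/c1cccc(F)c1` gives in this assay > 52000 nM, again a limit. Compound 3 `C=C[C@@](C)(/C=C/c1ccc(Nc2ccc(OC)c(OC)c2)cc1)CCC=C(C)C` gives in this assay > 52000 nM, also a limit. Among the measured compounds shown here, compound 1 thus stands where every measured value stands, at the limit of > 52000 nM in this assay, at which 3 of the 3 values shown sit, with no compound showing a number below it.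

Compound 4 `C=C[C@@](C)(/C=C/c1ccc(-c2ccccc2)cc1)CCC=C(C)C` differs from compound 1 by phenyl in place of methoxy on an aromatic carbon. For the measured compounds named here, no measured pair isolates the effect of such a change. Every measured value sits at the limit, and compounds 2 and 3 carry larger changes from the shared core than compound 4 does. The expected step from compound 1 to compound 4 is therefore a number no higher from compound 1 to compound 4 (the limit leaves the size open), nothing beyond the scatter. Compound 4 is expected to give about 52000 nM in this assay, with a range from 20000 nM to 150000 nM, and most likely to be reported once more only as a limit.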

Compound 4, half-maximal effective concentration: > 52000 nM
Compound 4: a limit, no number; the forecaster's own chance of this, stated with the estimate: 80%; the middle value lies on the limit itself.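

No step can be read from compound 1 to compound 4, as both are reported only as limits in this assay. The compounds shown leave open whether phenyl in place of methoxy changes cytotoxicity at all, and whether any change to the shared core gives a measurable value: the limit of > 52000 nM in this assay, at which 4 of the 4 values shown sit.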